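Linker length in the diester series: compound 4

The source may report more compounds than this note shows. Statements on the series, on what has been measured and on what is new or still open speak of the compounds shown alone.

Compound 3 `CCCC(=O)OCCOC(=O)c1ccc(C(=O)Nc2ccc3c(c2)C(C)(C)CCC3(C)C)cc1` gives 6290 nM in a functional assay on HL-60 cells (Homo sapiens) for inhibition, read by MTT assay, with a stated time of 48 h; on this read-out lower numbers stand for stronger inhibition and higher numbers for weaker inhibition. Compound 1 `CCCC(=O)OCCCCOC(=O)c1ccc(C(=O)Nc2ccc3c(c2)C(C)(C)CCC3(C)C)cc1` gives 7320 nM in this assay, and the step of a 1.2-fold lower number from compound 1 to compound 3 (0.07 log units; within the scatter) stays within the scatter, so compound 3 and compound 1 cannot be told apart on these numbers. Compound 2 `CCCC(CCC)C(=O)OCCCCOC(=O)c1ccc(C(=O)Nc2ccc3c(c2)C(C)(C)CCC3(C)C)cc1` gives 914000 nM in this assay; the steps of a 120-fold higher number from compound 1 to compound 2 (2.10 log units; beyond the scatter) and a 150-fold lower number from compound 2 to compound 3 (2.16 log units; beyond the scatter) are both large, but both turn on the acyl group, not on the saturated chain.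

Compound 4 `CCCC(=O)OCCCOC(=O)c1ccc(C(=O)Nc2ccc3c(c2)C(C)(C)CCC3(C)C)cc1` is the next member. The change from compound 3 is ((propylcarbonyl)oxy)methyl in place of (propylcarbonyl)oxy on a saturated chain carbon, two bonds along the chain from an oxygen next to a carbonyl group. Among the compounds with values here, the only measured step that bears on this kind of change is a 1.2-fold lower number from compound 1 to compound 3 (0.07 log units; within the scatter), which altered the same chain at the same place and stayed within the scatter. The acyl-group steps say nothing about the chain beyond showing that the series is sensitive elsewhere. With a single relevant step, and that one flat, the expected step of a 1.1-fold higher number from compound 3 to compound 4 (0.03 log units; within the scatter) is therefore none beyond the scatter, in no particular direction. Compound 4 is expected to sit with compound 1 and compound 3 in this assay. The estimate for compound 4 is 6800 nM, with a range from 3000 nM to 15000 nM.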

Compound 4, half-maximal inhibitory concentration: 2990 nM
For compound 4 the middle estimate is 2.3-fold (0.36 log units) above the measured one; the whole stated range lies above it.
By their numbers in this assay, from the lowest: compound 4; then compounds 3 and 1 (each within the scatter of the next); then compound 2.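

In this assay the saturated chain proves not to be flat after all: the steps (a 2.1-fold lower number from compound 3 to compound 4 (0.32 log units; beyond the scatter)) and (a 2.4-fold lower number from compound 1 to compound 4 (0.39 log units; beyond the scatter)) both lie beyond the scatter, whereas the earlier chain comparison alone showed nothing. The response to chain length is not a steady trend, since compound 3 with the shorter chain and compound 1 with the longer chain cannot be told apart, while compound 4 stands lower than both. The chain effect remains small beside the larger gap to the compound bearing the 1-propylbutyl acyl group (a 310-fold lower number from compound 2 to compound 4 (2.49 log units; beyond the scatter)), a step that spans both the acyl group and the chain, so it cannot be credited to the chain alone. No measurement at hand accounts for the lower number of compound 4.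

On these data alone, it remains open whether a longer chain than that of compound 1 would stay level with compound 1 or shift again, and whether the 3-((propylcarbonyl)oxy)propyl chain would also lower the number with a 1-propylbutyl acyl group. Equally open, as far as these compounds go, is how a terminal amine or carboxylic acid in place of the butanoate ester would read on this chain.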